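The source may hold more compounds than are shown below. What is called first, only, known or untested is meant among the compounds shown, and "the series" means these compounds.

Compound 1 `COc1ccc(-c2cnc(NC(=O)c3cnco3)n2C)cc1` belongs to a small set of compounds tested in a toxicity assay on THP-1 cells (Homo sapiens) for inhibition; on this read-out higher numbers stand for lower toxicity in this test and lower numbers for higher toxicity in this test. In this assay compound 1 gives > 100000 nM, which is a limit of the assay rather than a measured number. Compound 2 `Cn1c(-c2ccccc2Br)cnc1NC(=O)c1ccc(F)cc1`, which shares the core but carries other groups, gives > 100000 nM in this assay, again a limit. Both values shown therefore sit at the limit of > 100000 nM in this assay, at which 2 of the 2 values shown sit, so neither compound shows toxicity that this assay could put a number on, and compound 1 cannot be ranked against compound 2. Compound 3 `COc1ccc(-c2cnc(NC(=O)c3ccccc3OC)n2C)cc1` has not yet been measured in this assay. It differs from compound 1 in one place: 2-methoxyphenyl in place of 1,3-oxazol-5-yl on a carbonyl carbon. For the measured compounds named here, no step between two measured compounds is available to show what such an exchange does here. Because both measured values sit at the limit of > 100000 nM in this assay, at which 2 of the 2 values shown sit, the expected outcome is that the step of a number no higher from compound 1 to compound 3 (the limit leaves the size open) stays within the usual scatter, with neither direction favoured. Compound 3 is accordingly estimated at 100000 nM in this assay, within a range from 30000 nM to 300000 nM, and most likely reported once more only as a limit.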

Compound 3, half-maximal cytotoxic concentration: > 100000 nM
Compound 3 ended at the assay's limit (the forecaster's own chance of this, stated with the estimate: 75%); the middle value lies on the limit itself.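

For the compounds shown here, compound 3, like compound 1, sits at a limit of this assay rather than at a measured number, so no step between the two can be read: the limit of > 100000 nM in this assay, at which 3 of the 3 values shown sit.

Whether 2-methoxyphenyl in place of 1,3-oxazol-5-yl alters toxicity at all, and at what concentration any of these compounds would become toxic in this assay, remains open.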